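A few compounds are considered here, and "the series" means these few. Any claim that something is new, unique, unknown or untested is made for them only; others in the source may bear on it.

Measured so far:
Compound 1 `Nc1nccc(-c2sc(C3CCN3)nc2-c2cccc(NS(=O)(=O)c3cc(F)ccc3F)c2F)n1`: 32.8 nM
Compound 2 `Nc1nccc(-c2sc(C3CCCN3)nc2-c2cccc(NS(=O)(=O)c3cc(F)ccc3F)c2F)n1`: 11.2 nM

In a functional assay on A-375 cells (Homo sapiens) for inhibition, read by MTT assay, with a stated time of 5 days (on this read-out lower numbers stand for stronger inhibition and higher numbers for weaker inhibition), compound 2, at 11.2 nM, holds the lower of the two numbers. The compound still to be measured, compound 3 `Nc1nccc(-c2sc(C3CCCCN3)nc2-c2cccc(NS(=O)(=O)c3cc(F)ccc3F)c2F)n1`, keeps the shared core and differs from compound 2 in a single group: piperidin-2-yl in place of pyrrolidin-2-yl on an aromatic carbon.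

For the measured compounds named here, only one measured step bears on this change. It is a similar ring change on the same aromatic carbon, pyrrolidin-2-yl in place of azetidin-2-yl, and it gave a 2.9-fold lower number from compound 1 to compound 2 (0.47 log units; beyond the scatter). That modest step is a single example, and the data do not show whether a further ring enlargement would continue in the same direction. In this assay, a step no larger than that one is therefore expected, with no firm direction and quite possibly none beyond the scatter.

The expected step is a 1.3-fold higher number from compound 2 to compound 3 (0.10 log units; within the scatter). For compound 3 the estimated value is 14 nM, with an expected range of 5 nM to 40 nM.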

Compound 3, half-maximal inhibitory concentration: 5.12 nM
Beside the measured number, compound 3's estimate is 2.7-fold (0.44 log units) above it; low and high end bracket the measured number.
By their numbers in this assay, from the lowest: compound 3; then compound 2; then compound 1.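

In this assay the move to the six-membered ring gives a 2.2-fold lower number from compound 2 to compound 3 (0.34 log units; beyond the scatter) and so shows that the direction of the first ring enlargement holds for a second one at this position, on the aromatic carbon next to the ring nitrogen and the ring sulfur. Taken end to end, the series from azetidin-2-yl to piperidin-2-yl gives a 6.4-fold lower number from compound 1 to compound 3 (0.81 log units; beyond the scatter) and is a consistent run in which each added ring carbon lowers the number, with none of the three compounds going against it. Nothing measured here accounts for this trend, so the result describes the change without explaining it.

The compounds shown leave open whether the run continues to azepan-2-yl, with its seven-membered ring, or ends at piperidin-2-yl. They also leave open how much depends on the ring nitrogen and its place in the ring, which cyclohexyl, piperidin-3-yl, piperidin-4-yl or an open-chain amine such as aminomethyl at the same carbon would address.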